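Replacing nitro with methyl in compound 2

The source may hold more compounds than are shown below. What is called first, only, known or untested is meant among the compounds shown, and "the series" means these compounds.

In an ADME assay on MDCK cells (Canis lupus familiaris) for cytotoxicity, read by MTT assay, with a stated time of 72 h (on this read-out higher numbers stand for lower toxicity in this test and lower numbers for higher toxicity in this test), compound 2 `Cc1nc([N+](=O)[O-])cn1S(=O)(=O)c1ccc([N+](=O)[O-])cc1` gives 611000 nM. That number lies within the usual scatter of compound 3 `CC(=O)Nc1ccc(S(=O)(=O)n2cc([N+](=O)[O-])nc2C)cc1`, which gives 1030000 nM. Compound 1 `Cc1nc([N+](=O)[O-])cn1CC(=O)NCc1ccccc1` sits clearly lower, at 77600 nM.

Compound 4 `Cc1ccc(S(=O)(=O)n2cc([N+](=O)[O-])nc2C)cc1` keeps the shared core of compound 2 and alters one group, with methyl in place of nitro on an aromatic carbon. Going by the values given here, no measured compound carries this methyl yet, so the nearest guide is the one measured step that also removes this nitro. With acetamido in place of nitro, that step is a 1.7-fold higher number from compound 2 to compound 3 (0.23 log units; within the scatter), and it stays within the scatter. A single step is thin evidence, and acetamido is not methyl, but it gives no ground for expecting a large shift. The expected change is therefore a 1.3-fold higher number from compound 2 to compound 4 (0.12 log units; within the scatter), with no real movement beyond the scatter. For compound 4 the estimated value is 800000 nM, with an expected range from 300000 nM to 2000000 nM.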

Compound 4, half-maximal cytotoxic concentration: 988000 nM
The estimate for compound 4 lay 1.2-fold (0.09 log units) below the measured number; measured number inside the range.
By their numbers in this assay, from the lowest: compound 1; then compounds 2, 4 and 3 (each within the scatter of the next).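

In this assay, going by these compounds alone, methyl in place of nitro on an aromatic carbon gives a 1.6-fold higher number from compound 2 to compound 4 (0.21 log units; within the scatter), and this is the first step at this place, para to a large group, with a small carbon group as the newcomer. Methyl in place of acetamido gives a 1.0-fold lower number from compound 3 to compound 4 (0.02 log units; within the scatter), so nitro, acetamido and methyl now form a set of three groups with every step among them within the scatter, and the number shows no dependence on which of the three is present. Nothing measured here gives a reason for this flat result.

The compounds shown leave open whether an amine or a carboxylic acid at this place would move the number beyond the scatter. They also leave open whether a longer chain there would do so, or whether a change elsewhere on the shared core would matter more.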